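The source may hold more compounds than are shown below. What is called first, only, known or untested is meant among the compounds shown, and "the series" means these compounds.

Measured so far:
Compound 1, `O=C(NC(=S)NNc1ncnc2ccccc12)c1ccccc1`: 6990 nM
Compound 2, `O=C(NC(=S)NNc1ncnc2ccccc12)c1ccc(Cl)cc1`: 1860 nM
Compound 3, `COc1cc2ncnc(NNC(=S)NC(=O)c3cccc(Cl)c3)c2cc1OC`: 4060 nM

In a functional assay on MGC-803 cells (Homo sapiens) for cytotoxicity, read by MTT assay, with a stated time of 72 h (on this read-out lower numbers stand for stronger inhibition and higher numbers for weaker inhibition), compound 2 gives 1860 nM. Compound 1 carries the change hydrogen in place of chloro on an aromatic carbon and in this assay compound 1 gives 6990 nM, which is a 3.8-fold higher number from compound 2 to compound 1 (0.57 log units; beyond the scatter). Compound 3 has a different core, and the difference between the two cores is not broken down here; in this assay compound 3 gives 4060 nM.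

Compound 4, `COc1cc2ncnc(NNC(=S)NC(=O)c3ccccc3)c2cc1OC`, is not yet measured. It differs from compound 3 by hydrogen in place of chloro on an aromatic carbon. This is the same kind of change as that from compound 2 to compound 1, but there the place was para to a large group and here it is meta to a large group. Because the earlier step was a 3.8-fold higher number from compound 2 to compound 1 (0.57 log units; beyond the scatter), the step for compound 4 is expected to be a 2.5-fold higher number from compound 3 to compound 4 (0.39 log units; beyond the scatter), in the same direction but with wider uncertainty. Compound 4 is therefore estimated at 10000 nM, with a range from 4000 nM to 25000 nM.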

Compound 4, half-maximal inhibitory concentration: 3050 nM
The estimate for compound 4 lay 3.3-fold (0.52 log units) above the measured number, and the stated range ends above it.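

In this assay, hydrogen in place of chloro gives a 1.3-fold lower number from compound 3 to compound 4 (0.12 log units; within the scatter), so on this core the change has no effect that can be told from scatter. The step seen on the core of compound 1 did not carry over to the core of compound 3 at the same size: the same change on two cores in this assay, a 3.8-fold higher number (0.57 log units; beyond the scatter) from compound 2 to compound 1 and a 1.3-fold lower number (0.12 log units; within the scatter) from compound 3 to compound 4, 5.0-fold (0.70 log units) apart, beyond the scatter of two such steps. The chloro also stands at a different place on the ring in compound 2 than in compound 3, so this gap cannot be assigned to the core alone.

From the compounds shown here alone, it remains open how the two cores would compare with the chloro at the same place on the ring. Going by these compounds, it also remains open whether a fluoro, a methyl or a nitrile in its stead would behave as the chloro of compound 2 or that of compound 3 does.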